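This account rests on a few compounds, and the source may have more. Where it says the series, first, only, none or still open, it means among the compounds named here.

Working notes on the series.

Two analogues of the shared core have been measured. Compound 1 `O=C1N=C(N2N=C(c3ccccc3)CC2c2ccc(Cl)cc2)S/C1=C1/C(=O)Nc2ccccc21` carries a phenyl group on the carbon with a double bond to nitrogen of the five-membered ring; in a functional assay on cells (Cancer cell lines, Homo sapiens) for cytotoxicity, read by sulforhodamine B assay, with a stated time of 48 h (a higher number here means a weaker inhibitor of growth, a lower number a stronger inhibitor of growth), compound 1 gives 320 nM. Compound 2 `COc1ccc(C2=NN(C3=NC(=O)/C(=C4\C(=O)Nc5ccccc54)S3)C(c3ccc(Cl)cc3)C2)cc1` carries a 4-methoxyphenyl group at the same carbon; in this assay compound 2 gives 100000 nM. Among the compounds with values here, compound 2 thus stands as the higher of the two numbers, the only step known being a 310-fold higher number from compound 1 to compound 2 (2.49 log units; beyond the scatter).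

Compound 3 `O=C1N=C(N2N=C(c3ccc4ccccc4c3)CC2c2ccc(Cl)cc2)S/C1=C1/C(=O)Nc2ccccc21` differs from compound 2 in one place: naphthalen-2-yl in place of 4-methoxyphenyl on a carbon with a double bond to nitrogen. The step from compound 1 to compound 2 bears on this only in that the methoxy is removed again; nothing measured covers the second fused ring. Because a 310-fold higher number from compound 1 to compound 2 (2.49 log units; beyond the scatter) was large, a substantial drop toward compound 1 is expected, tempered by the unknown effect of the added ring.

For compound 3 the estimate in this assay is 2000 nM, range 300 nM to 30000 nM. That estimate means an expected step of a 50-fold lower number from compound 2 to compound 3 (1.70 log units; beyond the scatter).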

Compound 3, concentration for 50% growth inhibition: 740 nM
For compound 3 the middle estimate is 2.7-fold (0.43 log units) above the measured one, within the range that was stated.
By their numbers in this assay, from the lowest: compound 1; then compound 3; then compound 2.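

In this assay, the carbon with a double bond to nitrogen accepts a second fused ring: naphthalen-2-yl in place of 4-methoxyphenyl gives a 140-fold lower number from compound 2 to compound 3 (2.13 log units; beyond the scatter), and naphthalen-2-yl in place of phenyl gives only a 2.3-fold higher number from compound 1 to compound 3 (0.36 log units; beyond the scatter), a modest step. Size alone therefore does not track the large rise seen with 4-methoxyphenyl, as compound 3 carries the larger group by heavy atom count yet sits far nearer to compound 1 than compound 2 does. Nothing at hand explains why these two aryl groups read so differently.

On these data alone, whether the large rise belongs to the methoxy group itself or to any substituent on that phenyl ring remains open. A hydroxyl, an amine or a fluorine in place of the methoxy would separate these readings, and naphthalen-1-yl would test how the fused ring is attached.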